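Benzoyl ester in place of cyclohexylmethyl ether on the core

The source may hold more compounds than are shown below. What is called first, only, known or untested is meant among the compounds shown, and "the series" means these compounds.

Measured compounds:
compound 1, `CCC1(Cc2ccccc2)OS(=O)(=O)C=C1OCCCCc1ccccc1`: 99000 nM
compound 2, `CCC1(Cc2ccccc2)OS(=O)(=O)C=C1OCC1CCCCC1`: > 200000 nM
compound 3, `CCC1(Cc2ccccc2)OS(=O)(=O)C=C1NCc1ccccc1`: 92000 nM

Three compounds share the core of compound 1 and differ only in the group on the double-bonded ring carbon. In an ADME assay on HEL cells (Homo sapiens) for cytotoxicity, with a stated time of 3 days (on this read-out lower numbers stand for higher toxicity in this test and higher numbers for lower toxicity in this test), compound 1 gives 99000 nM. For compound 2 the assay reports only a limit, > 200000 nM. Compound 3 gives 92000 nM. Compound 2 therefore stands at the top of the numbers shown, at the point where one of the three values sits (the limit of > 200000 nM in this assay, at which 1 of the 3 values shown sits). The two measured steps that touch it are an at least 2.0-fold higher number from compound 1 to compound 2 (0.30 log units; that floor lies within the scatter), which is benzoyl in place of cyclohexylmethyl on an oxygen on an unsaturated carbon -like in its place but not in its groups, and an at least 2.1-fold lower number from compound 2 to compound 3 (0.33 log units; beyond the scatter); the first lies within the scatter, the second goes beyond it.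

Compound 4, `CCC1(Cc2ccccc2)OS(=O)(=O)C=C1OC(=O)c1ccccc1`, differs from compound 2 by benzoyl in place of cyclohexylmethyl on an oxygen on an unsaturated carbon. Both measured neighbours of compound 2 that carry an aromatic ring in this position sit below its limit, so the change to a benzoyl group is expected to carry compound 4 back toward those values, a step of an at least 1.6-fold lower number from compound 2 to compound 4 (0.22 log units; that floor lies within the scatter). Compound 4 is estimated at 120000 nM, with a range from 60000 nM to 250000 nM.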

Compound 4, half-maximal cytotoxic concentration: > 200000 nM
Compound 4: only a limit was reported (the forecaster's own chance of this, stated with the estimate: 35%); at least 1.6-fold (0.22 log units) between middle value and limit.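

In this assay compound 4 gives only a limit, > 200000 nM. Compound 2 also gives only a limit, > 200000 nM. Among the compounds shown here, no step from compound 2 to compound 4 can be read from these two limits. The compounds shown leave open how compound 2 and compound 4 stand relative to each other, and whether benzoyl in place of cyclohexylmethyl changes the read-out at all.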